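Changing the amide group of compound 3

The source may hold more compounds than are shown below. What is called first, only, known or untested is meant among the compounds shown, and "the series" means these compounds.

Measured so far in an ADME assay on MT4 cells (Homo sapiens) for cytotoxicity, read by MTT assay (on this read-out higher numbers stand for lower toxicity in this test and lower numbers for higher toxicity in this test), each value a limit:
Compound 1 `Cc1cc(C)cc(S(=O)(=O)c2c(C(=O)NCc3cccc(F)c3F)[nH]c3ccc(Cl)cc23)c1`: > 51100 nM
Compound 2 `Cc1cc(C)cc(S(=O)(=O)c2c(C(=O)NC(c3ccc(Cl)cc3)C3CC3)[nH]c3ccc(Cl)cc23)c1`: > 47300 nM
Compound 3 `Cc1cc(C)cc(S(=O)(=O)c2c(C(=O)Nc3cc(C#N)ccn3)[nH]c3ccc(Cl)cc23)c1`: > 53700 nM

Compound 3 stands at > 53700 nM, which is a limit and not a number. The other two values shown are limits too, so these figures do not rank the three compounds.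

Compound 4 `Cc1cc(C)cc(S(=O)(=O)c2c(C(=O)NCc3ccc4nc(N)[nH]c4c3)[nH]c3ccc(Cl)cc23)c1` keeps the shared core and differs only on the amide-type nitrogen. The change is a group of 11 heavy atoms (8 carbon, 3 nitrogen; one five-membered aromatic ring with 2 hetero atoms, one six-membered aromatic ring of carbon only) in place of a group of 8 heavy atoms (6 carbon, 2 nitrogen; one six-membered aromatic ring with 1 hetero atom), on an amide-type nitrogen.

Three measured steps change a group at this same place. They are a step that the two limits leave unreadable from compound 1 to compound 2, a step that the two limits leave unreadable from compound 1 to compound 3 and a step that the two limits leave unreadable from compound 2 to compound 3. With their sizes unreadable, these steps offer no definite size to carry over, so only a cautious allowance is expected towards lower numbers in this assay. The expected change is an at least 1.7-fold lower number from compound 3 to compound 4 (0.25 log units; that floor lies within the scatter), an estimate only. For compound 4 the estimated value is 30000 nM, with an expected range from 7000 nM to 48000 nM.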

Compound 4, half-maximal cytotoxic concentration: 5890 nM
The estimate for compound 4 lay 5.1-fold (0.71 log units) above the measured number, and the stated range ends above it.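

In this assay, among the compounds shown here, compound 4 gives the first true number for a change on the amide-type nitrogen, and this shows that the group placed here can shift the read-out towards higher toxicity in this test, with an at least 9.1-fold lower number from compound 3 to compound 4 (0.95 log units; beyond the scatter). The same shift appears against the other two groups, with an at least 8.0-fold lower number from compound 2 to compound 4 (0.90 log units; beyond the scatter) and with an at least 8.6-fold lower number from compound 1 to compound 4 (0.93 log units; beyond the scatter). Each size is only a floor, since the true gaps may be larger, and the steps among compound 1, compound 2 and compound 3 cannot be read.

Nothing measured here accounts for the drop in compound 4. The compounds shown also leave open whether the amino group of the entering group matters, which a methyl or hydroxyl group in its place on the same rings would test.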